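Piperazine Dithiocarbamate Benzamides: Methyl to Pyrazinyl Substitution

The source may report more compounds than this note shows. Statements on the series, on what has been measured and on what is new or still open speak of the compounds shown alone.

Measured compounds:
compound 1 `COc1ccc(N2CCN(C(=S)SCc3ccc(C(=O)Nc4ccccc4N)cc3)CC2)cc1` — 35.9%
compound 2 `CN1CCN(C(=S)SCc2ccc(C(=O)Nc3ccccc3N)cc2)CC1` — 91.6%

In a functional assay on A-375 cells (Homo sapiens) for antiproliferative activity, read by CCK-8 assay, with a stated time of 72 h, tested at 8 uM (a higher number here means a stronger effect of the compound at the concentration tested, a lower number a weaker effect), compound 2 gives 91.6%, the higher of the two numbers measured; compound 1 gives 35.9%. Within the data shown here, the single step between them, a number 55.7 percentage points higher from compound 1 to compound 2 (beyond the scatter), was large and beyond the scatter.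

Compound 3 `Nc1ccccc1NC(=O)c1ccc(CSC(=S)N2CCN(c3cnccn3)CC2)cc1` is not yet measured. It differs from compound 2 by pyrazin-2-yl in place of methyl on an amine nitrogen in a ring. Among the measured compounds shown here, the one measured step bears on this change only in reverse: replacing an aryl group on that ring nitrogen with methyl raised the number, so putting an aryl group back in place of methyl would be expected to lower it, though pyrazin-2-yl is not 4-methoxyphenyl and the size of the effect is uncertain. Compound 3 is therefore expected to sit below compound 2, with an estimated 55% (range 25% to 85%), a step of a number 36.6 percentage points lower from compound 2 to compound 3 (beyond the scatter) expected in this assay.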

Compound 3, a percentage reported as inhibition, at one concentration (the size of the read-out at that concentration, not a potency): 85.8%
The estimate for compound 3 lay 30.8 percentage points below the measured number, and the stated range ends below it.
By their numbers in this assay, from the lowest: compound 1; then compounds 3 and 2 (each within the scatter of the next).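

In this assay, the step, a number 5.8 percentage points lower from compound 2 to compound 3 (within the scatter), shows that the amine nitrogen in the ring can carry pyrazin-2-yl, with its six-membered aromatic ring, and give a read-out within the scatter of the one given with methyl. The step, a number 49.9 percentage points higher from compound 1 to compound 3 (beyond the scatter), compares two aromatic groups at this same place, so among the compounds shown the large drop goes with 4-methoxyphenyl and not with an aromatic ring as such. Nothing available here accounts for the wide gap between these two aromatic groups.

The compounds shown leave open whether an unsubstituted phenyl group or a pyridin-2-yl ring on this nitrogen would stand with compound 1 or with compound 3. They also leave open what a longer chain, such as ethyl or hydroxyethyl, would give at this place.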